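This account rests on a few compounds, and the source may have more. Where it says the series, first, only, none or still open, it means among the compounds named here.

Three compounds have been measured in a functional assay on MDA-MB-231 cells (Homo sapiens) for cytotoxicity, read by neutral red uptake, with a stated time of 72 h; on this read-out lower numbers stand for stronger inhibition and higher numbers for weaker inhibition:

compound 1, `CCCCCCNc1nc(SCC)nc2ncccc12`: 1400 nM
compound 2, `CCCCCCNc1nc(SC(C)C)nc2ncccc12`: 4500 nM
compound 3, `CCCCNc1nc(SCCCC)nc2ncccc12`: 8400 nM

Compound 1 and compound 2 share one core and differ in a single place, (methyl in place of hydrogen on a saturated chain carbon bound to a saturated chain carbon and a sulfur). That change brought a 3.2-fold higher number from compound 1 to compound 2 (0.51 log units; beyond the scatter). Compound 3 is built from the same atoms as compound 1, joined differently; the difference between the two cores is not broken down here. Compound 3 gives the highest number of the three, but its gap to compound 2 lies within the usual scatter of repeated measurements, while its gap to compound 1 lies beyond it.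

Compound 4, `CCCCCNc1nc(SCCCC)nc2ncccc12`, has not yet been measured. It differs from compound 3 in one place, (methyl in place of hydrogen on a saturated chain carbon, four bonds along the chain from a nitrogen on an aromatic ring). Among the compounds with values here, this is the same kind of change as the one from compound 1 to compound 2, but not the same: there the methyl entered on a saturated chain carbon bound to a saturated chain carbon and a sulfur, here it enters on a saturated chain carbon, four bonds along the chain from a nitrogen on an aromatic ring. Within the data shown here, no measured pair shows a change at this place, so the earlier step is only a loose guide. The step from compound 3 to compound 4 is expected to be small, roughly a 1.4-fold lower number from compound 3 to compound 4 (0.15 log units; within the scatter). Compound 4 is therefore estimated at about 6000 nM in this assay, likely between 2500 nM and 15000 nM.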

Compound 4, half-maximal inhibitory concentration: 6300 nM
Compound 4: middle estimate off by 1.1-fold (0.02 log units), on the low side; the range from low to high includes it.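

In this assay, the newly measured pair shows a 1.3-fold lower number from compound 3 to compound 4 (0.12 log units; within the scatter), so a methyl in place of hydrogen at this place leaves the two numbers too close to tell apart. Set beside the earlier step, this result shows that the change does not carry over from one core to another as a single fixed step: the same change on two cores in this assay, a 3.2-fold higher number (0.51 log units; beyond the scatter) from compound 1 to compound 2 and a 1.3-fold lower number (0.12 log units; within the scatter) from compound 3 to compound 4, 4.3-fold (0.63 log units) apart, beyond the scatter of two such steps

What the comparison does not show is why the steps differ, since the two pairs differ in more than their cores: in the earlier pair the methyl enters on a saturated chain carbon bound to a saturated chain carbon and a sulfur, and in the new pair it enters on a saturated chain carbon, four bonds along the chain from a nitrogen on an aromatic ring, so the effects of place and core cannot be separated here.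

A pair carrying the methyl at the same place on two different cores would be needed to separate them. The compounds shown also leave open how this read-out would respond to a longer chain on the nitrogen or the sulfur, or to an amine or a carboxylic acid at the end of either chain.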